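Cytotoxicity in the benzylsulfanyl series: a bromo analogue

The source may hold more compounds than are shown below. What is called first, only, known or untested is meant among the compounds shown, and "the series" means these compounds.

Compound 1 `Cn1c(SCc2ccccc2)nnc1-c1cc([N+](=O)[O-])cc([N+](=O)[O-])c1` is the parent of this small set. In an ADME assay on A-431 cells (Homo sapiens) for cytotoxicity, with a stated time of 48 h (on this read-out lower numbers stand for stronger inhibition and higher numbers for weaker inhibition), compound 1 gives only a limit, > 30000 nM. Compound 2 `CCn1c(SCc2ccccc2)nnc1-c1cc([N+](=O)[O-])cc([N+](=O)[O-])c1` carries methyl in place of hydrogen on a saturated chain carbon bound to an aromatic nitrogen; in this assay compound 2 likewise returns a limit, > 30000 nM. Compound 3 `O=[N+]([O-])c1cc(-c2nnc(SCc3ccccc3)n2Cc2ccccc2)cc([N+](=O)[O-])c1` carries phenyl in place of hydrogen on a saturated chain carbon bound to an aromatic nitrogen, and in this assay compound 3 also reaches only a limit, > 30000 nM. The steps a step that the two limits leave unreadable from compound 1 to compound 2, a step that the two limits leave unreadable from compound 1 to compound 3 and a step that the two limits leave unreadable from compound 2 to compound 3 are therefore all without readable size or direction, because of the limit of > 30000 nM in this assay, at which 3 of the 3 values shown sit.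

Compound 4 `Cn1c(SCc2ccc(Br)cc2)nnc1-c1cc([N+](=O)[O-])cc([N+](=O)[O-])c1` differs from compound 1 in one place: bromo in place of hydrogen on an aromatic carbon. For the measured compounds named here, none of the measured steps touches the benzylsulfanyl group, and the three that exist sit at the same limit, so no step size or direction can be carried over to the bromo change. Compound 4 is expected to sit at the limit as well, with the step that the limit leaves unreadable from compound 1 to compound 4 expected to show nothing beyond the scatter. The estimate for compound 4 in this assay is 50000 nM, within 20000 nM to 150000 nM.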

Compound 4, half-maximal inhibitory concentration: > 30000 nM
Compound 4: a limit, no number; the forecaster's own chance of this, stated with the estimate: 85%; the middle value is on the limit's open side.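

No step can be read from compound 1 to compound 4 in this assay, so the bromo change has no readable size or direction, because both values are limits: the limit of > 30000 nM in this assay, at which 4 of the 4 values shown sit. The compounds shown leave open whether any change to the shared core would bring cytotoxicity to a measurable value.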